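The compounds below may be only part of what the source reports. "The series", "measured", "known", "first", "only" and "open" are said of these compounds alone.

Measured compounds:
compound 1, `COc1ccc(N)c(C(O)CCNC(C)=N)c1`, 57.4%
compound 2, `COc1ccc(N)c(C(O)CCNC(=N)c2ccccc2)c1`, 95.9%
compound 3, `COc1ccc(N)c(C(=O)CCNC(C)=N)c1`, 97.6%

All three were tested in an assay for inhibition of Nitric oxide synthase, inducible (Homo sapiens), with a stated time of 30 min, tested at 1 mM; a lower number here means less inhibition, a higher number more inhibition at the concentration tested (going by the name of the read-out). For the measured compounds named here, the one measured step between compounds differing in a single place is a number 38.5 percentage points higher from compound 1 to compound 2 (beyond the scatter), and it goes with phenyl in place of methyl on a carbon with a double bond to nitrogen. The same change turns compound 3 into compound 4, `COc1ccc(N)c(C(=O)CCNC(=N)c2ccccc2)c1`, which has not yet been measured: phenyl in place of methyl on a carbon with a double bond to nitrogen. The difference between the core of compound 1 and the core of compound 3 is not broken down here. Compound 2 and compound 3 lie within the usual scatter of each other in this assay.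

The earlier step was large, but it started from a much lower value. Little room for a rise of that size is left because compound 3 already gives 97.6% in this assay. A step near the top of the scale is expected to be small: a number 0.4 percentage points higher from compound 3 to compound 4 (within the scatter). Compound 4 is therefore expected to give about 98%, most likely between 93% and 100%.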

Compound 4, a percentage reported as inhibition, at one concentration (the size of the read-out at that concentration, not a potency): 94.7%
Estimate against measurement, compound 4: 3.3 percentage points above; measured number inside the range.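

In this assay, putting phenyl in place of methyl on a carbon with a double bond to nitrogen gives a number 2.9 percentage points lower from compound 3 to compound 4 (within the scatter), and the same change behaves differently on the two cores: the same change on two cores in this assay, a number 38.5 percentage points higher (beyond the scatter) from compound 1 to compound 2 and a number 2.9 percentage points lower (within the scatter) from compound 3 to compound 4, 41.4 percentage points apart, beyond the scatter of two such steps

The large rise seen on the core of compound 1 therefore does not carry over to the core of compound 3, where compound 3 already gives 97.6%. This does not show that methyl and phenyl give an equally strong effect on that core, since a reading near the top of the scale at a single concentration cannot separate them, and two pairs give no general rule for other cores.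

The compounds shown leave open how a group such as ethyl or cyclohexyl would behave in place of methyl or phenyl, and whether a longer chain would alter the picture. They also leave open how compound 3 and compound 4 would compare at a lower concentration or in a full potency measurement.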